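The source may report more compounds than this note shows. Statements on the series, on what has been measured and on what is new or still open speak of the compounds shown alone.

Working notes on the series in a toxicity assay on MCF-10A cells (Homo sapiens) for cytotoxicity, read by MTT assay, with a stated time of 48 h; on this read-out lower numbers stand for stronger inhibition and higher numbers for weaker inhibition. All compounds share the core of compound 1 `Cn1cccc1C(=O)/C=C/c1ccc2c(c1)B(O)OC2` and differ only in the group on the carbonyl carbon. For compound 1 this assay returns only a limit, > 100000 nM, not a number. Compound 2 `O=C(/C=C/c1ccc2c(c1)B(O)OC2)c1ccc(F)cc1` gives 11800 nM in this assay. Going by the values given here, compound 3 `O=C(/C=C/c1ccc2c(c1)B(O)OC2)c1ccccc1F` gives 25400 nM in this assay, the highest of the two numbers recorded; its nearest neighbour is compound 2, and the step of a 2.2-fold higher number from compound 2 to compound 3 (0.33 log units; beyond the scatter) is the only one between two actual numbers. The steps of an at least 8.4-fold lower number from compound 1 to compound 2 (0.92 log units; beyond the scatter) and an at least 3.9-fold lower number from compound 1 to compound 3 (0.59 log units; beyond the scatter) start from a limit and so set no finished size, noted under (the limit of > 100000 nM in this assay, at which 1 of the 3 values shown sits).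

Compound 4 `O=C(/C=C/c1ccc2c(c1)B(O)OC2)c1cccc(F)c1` is not yet measured. The change from compound 3 is 3-fluorophenyl in place of 2-fluorophenyl on a carbonyl carbon. Among the compounds with values here, no measured step moves the fluorine between the 2-position and the 3-position of the phenyl, so the only bearing comes from the step of a 2.2-fold higher number from compound 2 to compound 3 (0.33 log units; beyond the scatter), which shows that moving the fluorine around the phenyl ring shifts this read-out by a modest amount. A step of similar or smaller size is therefore expected, in either direction, with compound 4 most likely landing between the numbers of compound 2 and compound 3.

Compound 4 is estimated at 18000 nM in this assay, with a range of 8000 nM to 45000 nM. The expected step is a 1.4-fold lower number from compound 3 to compound 4 (0.15 log units; within the scatter).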

Compound 4, half-maximal inhibitory concentration: 15800 nM
Compound 4: the middle estimate sits 1.1-fold (0.06 log units) above what was measured; the measured number falls inside the stated range.
By their numbers in this assay, from the lowest: compounds 2, 4 and 3 (each within the scatter of the next, the first and the last beyond it). At a limit, above all of these: compound 1.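

In this assay, the step of a 1.6-fold lower number from compound 3 to compound 4 (0.21 log units; within the scatter) and the step of a 1.3-fold higher number from compound 2 to compound 4 (0.13 log units; within the scatter) both stay within the scatter, so 3-fluorophenyl on the carbonyl carbon cannot be told apart from either 2-fluorophenyl or 4-fluorophenyl. The step of a 2.2-fold higher number from compound 2 to compound 3 (0.33 log units; beyond the scatter) remains the only one among the three fluorophenyl compounds that lies beyond the scatter, so the series shows no graded order that places compound 4 relative to the other two. Compound 1 stands at a limit, so the step of an at least 6.3-fold lower number from compound 1 to compound 4 (0.80 log units; beyond the scatter) sets no finished size and shows only that 3-fluorophenyl, like the other two fluorophenyl groups, gives a measurable number where 1-methyl-1H-pyrrol-2-yl does not: the limit of > 100000 nM in this assay, at which 1 of the 4 values shown sits.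

From the compounds shown here alone, what an unsubstituted phenyl, a chlorophenyl or a phenyl carrying an amine or a carboxylic acid would give on the carbonyl carbon in this assay stays open, and so does whether the fluorine itself matters for the number reached. The compounds shown vary only the group on the carbonyl carbon, so the contribution of the shared core also remains unknown.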